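Replacing the nitrogen-rich group on the shared core of compound 2

This account rests on a few compounds, and the source may have more. Where it says the series, first, only, none or still open, it means among the compounds named here.

Compound 2 `CNC(=N)Nc1nc(-c2ccc(OC)cc2)c(-c2ccc(OC)cc2)s1` is one of three measured analogues built on a shared core carrying two 4-methoxyphenyl groups. In a functional assay with Oryctolagus cuniculus as the target (on this read-out higher numbers stand for weaker inhibition and lower numbers for stronger inhibition), compound 2 gives 62 nM. It stands second highest of the three numbers: compound 3 `COc1ccc(-c2nc(/N=C(\N)N(C)C)sc2-c2ccc(OC)cc2)cc1` gives 37 nM, and a 1.7-fold lower number from compound 2 to compound 3 (0.22 log units; within the scatter); compound 1 `COc1ccc(-c2nc(N=C(N)N)sc2-c2ccc(OC)cc2)cc1` gives 31000 nM, and a 500-fold lower number from compound 1 to compound 2 (2.70 log units; beyond the scatter).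

Compound 4 `COc1ccc(-c2nc(CNC(=O)NC(C)C)sc2-c2ccc(OC)cc2)cc1` differs from compound 2 in one place: a group of 8 heavy atoms (5 carbon, 2 nitrogen, 1 oxygen; no ring) in place of a group of 5 heavy atoms (2 carbon, 3 nitrogen; no ring), on an aromatic carbon. The group that leaves in this change is the same one that was altered in the measured steps, so those steps are the ones that bear on it. Both a 500-fold lower number from compound 1 to compound 2 (2.70 log units; beyond the scatter) and an 840-fold lower number from compound 1 to compound 3 (2.92 log units; beyond the scatter) were large, showing that this position controls the number strongly, while a 1.7-fold lower number from compound 2 to compound 3 (0.22 log units; within the scatter) stayed within the scatter. Among the compounds with values here, in compound 4 the group that gave the strong numbers of compound 2 and compound 3 is gone entirely, and nothing among the measured compounds shows what such a replacement does. The expectation is therefore a step beyond the scatter toward a higher number, with wide uncertainty: the estimated step is a 32-fold higher number from compound 2 to compound 4 (1.51 log units; beyond the scatter), and compound 4 is expected to give about 2000 nM, within a range from 150 nM to 30000 nM.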

Compound 4, half-maximal inhibitory concentration: 42 nM
Compound 4: middle estimate off by 48-fold (1.68 log units), on the high side, and the stated range ends above it.
By their numbers in this assay, from the lowest: compounds 3, 4 and 2 (each within the scatter of the next); then compound 1.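

In this assay, the step of a 1.5-fold lower number from compound 2 to compound 4 (0.17 log units; within the scatter) and the step of a 1.1-fold higher number from compound 3 to compound 4 (0.06 log units; within the scatter) both stay within the scatter, so the ((isopropylcarbamoyl)amino)methyl group serves as well at this position as the groups it is compared with. A low number here therefore does not depend on keeping the nitrogen-rich groups of compound 2 and compound 3, since a group with a carbonyl and a different count of atoms matches them. The step of a 740-fold lower number from compound 1 to compound 4 (2.87 log units; beyond the scatter) is as large as the earlier steps away from compound 1, which leaves compound 1 as the only one of the four with a high number, and no measurement available here offers a reason for either finding.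

As far as these compounds go, what remains open is which part of the new group matters, for instance whether a methyl or a longer chain could stand in place of the isopropyl end with the number staying in the same range. From the compounds shown here alone, it is also open whether a much simpler group at this position, such as an aminomethyl group or a carboxylic acid, would keep the number low or bring it up toward that of compound 1.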